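Swapping One Amide Group on a Shared Core

A few compounds are considered here, and "the series" means these few. Any claim that something is new, unique, unknown or untested is made for them only; others in the source may bear on it.

Three amides sharing one core have been tested in a functional assay on MCF7 cells (Homo sapiens) for inhibition, read by MTT assay, with a stated time of 48 h; a lower number here means a stronger inhibitor, a higher number a weaker inhibitor. Compound 1 `CCNC(=O)/C=C/c1c(/C=C/c2ccc(OC)cc2)cc(OC)cc1OC` gives 7060 nM, compound 2 `CCCCCCCCNC(=O)/C=C/c1c(/C=C/c2ccc(OC)cc2)cc(OC)cc1OC` gives 4280 nM, and compound 3 `COc1ccc(/C=C/c2cc(OC)cc(OC)c2/C=C/C(=O)N2CCC(c3ccccc3)CC2)cc1` gives 4230 nM. On these numbers compound 3 stands together with the other two, and the scatter of the measurements does not separate any of them.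

The next compound, compound 4 `COc1ccc(/C=C/c2cc(OC)cc(OC)c2/C=C/C(=O)N2CCCC(C)C2)cc1`, has not yet been measured. It keeps the shared core but carries 3-methylpiperidin-1-yl in place of 4-phenylpiperidin-1-yl on a carbonyl carbon.

The most relevant evidence comes from the earlier swaps at that same carbonyl carbon, which gave a 1.7-fold lower number from compound 1 to compound 3 (0.22 log units; within the scatter) and a 1.0-fold lower number from compound 2 to compound 3 (0.01 log units; within the scatter). The change on the amide chain gave a 1.6-fold lower number from compound 1 to compound 2 (0.22 log units; within the scatter). Across these three compounds, then, quite different groups have left the number in this assay within the scatter. None of them carries 3-methylpiperidin-1-yl, however, so the comparison is only indirect.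

No step beyond the scatter is therefore expected, in either direction. The expected result is a 1.2-fold higher number from compound 3 to compound 4 (0.07 log units; within the scatter). For compound 4 the estimated value is 5000 nM, with an expected range from 2800 nM to 9000 nM.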

Compound 4, half-maximal inhibitory concentration: 11900 nM
Compound 4: the middle estimate sits 2.4-fold (0.38 log units) below what was measured; measured number outside the range, above it.
By their numbers in this assay, from the lowest: compounds 3, 2, 1 and 4 (each within the scatter of the next, the first and the last beyond it).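

Going by these compounds alone, at this carbonyl carbon the choice of amide group can move the number in this assay after all: replacing 4-phenylpiperidin-1-yl, with its 12 heavy atoms and aromatic ring, by 3-methylpiperidin-1-yl, with 7 heavy atoms and no aromatic ring, gives a 2.8-fold higher number from compound 3 to compound 4 (0.45 log units; beyond the scatter) and replacing octylamino by the same group gives a 2.8-fold higher number from compound 2 to compound 4 (0.44 log units; beyond the scatter) while no step among compounds 1, 2 and 3 had gone beyond the scatter. The change does not separate compound 4 from every earlier amide, since ethylamino and 3-methylpiperidin-1-yl differ by a 1.7-fold higher number from compound 1 to compound 4 (0.23 log units; within the scatter) and so compound 1 and compound 4 stand together in this assay. No measurement offered here accounts for the step seen with compound 4.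

The compounds shown leave open whether the step from compound 3 follows from losing the phenyl ring, from the methyl group, or from where that group sits on the piperidine ring. Plain piperidin-1-yl and 4-methylpiperidin-1-yl at the same carbonyl carbon would help to pull these apart, and an amine or a carboxylic acid on the phenyl ring of 4-phenylpiperidin-1-yl remains untested ground here.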